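Swapping an alkyl for a nitrile on a weak aorta series

The source may report more compounds than this note shows. Statements on the series, on what has been measured and on what is new or still open speak of the compounds shown alone.

Measured compounds:
compound 1 `Cc1cnc(-c2nn(Cc3ccccc3F)c3ncccc23)nc1N` 675000 nM
compound 2 `CC(C)(C)c1cnc(-c2nn(Cc3ccccc3F)c3ncccc23)nc1N` 709000 nM
compound 3 `Nc1nc(-c2nn(Cc3ccccc3F)c3ncccc23)ncc1C1CCCC1` 904000 nM

In a functional assay (aorta) with Oryctolagus cuniculus as the target (a higher number here means a weaker inhibitor, a lower number a stronger inhibitor), compound 3 gives the highest of the three numbers, but the steps leading to it, a 1.3-fold higher number from compound 2 to compound 3 (0.11 log units; within the scatter) and a 1.3-fold higher number from compound 1 to compound 3 (0.13 log units; within the scatter), both sit within the scatter, as does a 1.1-fold higher number from compound 1 to compound 2 (0.02 log units; within the scatter). Compound 4 `N#Cc1cnc(-c2nn(Cc3ccccc3F)c3ncccc23)nc1N` has not yet been measured. The change is cyano in place of cyclopentyl on an aromatic carbon. None of the three measured steps involves a cyano group; they only show that exchanging one alkyl group for another at this position left this assay unchanged. On that basis the step of a 1.1-fold lower number from compound 3 to compound 4 (0.05 log units; within the scatter) is expected to stay within the scatter. Compound 4 is therefore estimated at 800000 nM, with a range from 300000 nM to 2500000 nM.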

Compound 4, half-maximal inhibitory concentration: 391000 nM
Beside the measured number, compound 4's estimate is 2.0-fold (0.31 log units) above it, and the stated range covers the measured number.
By their numbers in this assay, from the lowest: compounds 4, 1, 2 and 3 (each within the scatter of the next, the first and the last beyond it).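

In this assay, among these compounds, cyano is the first group at this position, ortho to an amino group, whose step clears the scatter, with a 2.3-fold lower number from compound 3 to compound 4 (0.36 log units; beyond the scatter) as cyclopentyl leaves. The same exchange gives a 1.8-fold lower number from compound 2 to compound 4 (0.26 log units; within the scatter) from tert-butyl and a 1.7-fold lower number from compound 1 to compound 4 (0.24 log units; within the scatter) from methyl and both stay within the scatter, so the change stands out against only one of the three alkyl groups. Nothing measured here accounts for this difference. From the compounds shown here alone, whether an amine, a methoxy group or a carboxylic acid at this position would take the number lower stays open.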